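Replacing an Amino Group with Isopropyl(methyl)amino on Compound 1

The source may report more compounds than this note shows. Statements on the series, on what has been measured and on what is new or still open speak of the compounds shown alone.

Of the compounds shown here, two have been measured in a functional assay on the whole organism with Rattus norvegicus as the target; a lower number here means that less compound is needed, a higher number that more compound is needed for the effect. Among the measured compounds shown here, compound 1, `CCOC(=O)C(=O)Nc1cccc(N)c1C#N`, is the one with the lowest number of the two: in this assay compound 1 gives 0.05 mg/kg. Compound 2, `CCOC(=O)C(=O)Nc1cc(N(C)C)ccc1C#N`, gives 1.9 mg/kg in this assay, a number well above that of compound 1, a gap beyond the scatter. For the measured compounds named here, compound 2 differs from compound 1 in more than one place, so no single structural step connects them; the two values only show how far apart these two compounds lie.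

Compound 3, `CCOC(=O)C(=O)Nc1cccc(N(C)C(C)C)c1C#N`, has not yet been measured. It differs from compound 1 in one place: isopropyl(methyl)amino in place of amino on an aromatic carbon.

Going by the values given here, no measured pair shows this exact change, so its size is uncertain. Among the compounds with values here, the only other measured compound carrying a dialkylamino group is compound 2, which gives 1.9 mg/kg in this assay, so a higher number for compound 3 seems more likely than a lower one. The step from compound 1 to compound 3 is therefore expected to be an 8.0-fold higher number from compound 1 to compound 3 (0.90 log units; beyond the scatter) in this assay. Compound 3 is estimated at 0.4 mg/kg, within a range of 0.08 mg/kg to 3 mg/kg.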

Compound 3, dose for half-maximal effect: 0.3 mg/kg
The estimate for compound 3 lay 1.3-fold (0.12 log units) above the measured number; the measured number falls inside the stated range.
By their numbers in this assay, from the lowest: compound 1; then compound 3; then compound 2.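

Placing isopropyl(methyl)amino in place of amino on the aromatic carbon ortho to a cyano group gives a 6.0-fold higher number from compound 1 to compound 3 (0.78 log units; beyond the scatter) in this assay, and this is the first single-place change that can be read in this set. It shows that the number in this whole-animal test depends on what this position carries, although compound 3 at 0.3 mg/kg still gives a measurable effect with the larger group in place. The swap replaces a group with one hydrogen-bond donor by a group with none and also raises the heavy-atom count from one to five, and no measurement here gives a reason for the step.

The two changes arrive together, so the compounds shown cannot tell whether the loss of the donor or the added carbons accounts for the higher number. A methylamino group on the same carbon, which keeps a hydrogen-bond donor while adding a single carbon, would help to separate the two, and a longer chain on that nitrogen would show how far the trend extends.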